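Benzyl for Cyclohexyl on a Shared Imidazopyrazine-Benzimidazole Pair

The source may report more compounds than this note shows. Statements on the series, on what has been measured and on what is new or still open speak of the compounds shown alone.

Measured so far:
Compound 1, `O=Cc1ccc(-c2cn3ccnc3c(-c3ccc4ncn(C5CCCCC5)c4c3)n2)cc1`, gives 0.53% in a functional assay on NCI-H226 cells (Homo sapiens) for inhibition, read by sulforhodamine B assay, with a stated time of 48 h, tested at 10 uM; a lower number here means less inhibition, a higher number more inhibition at the concentration tested (going by the name of the read-out).
Compound 2, `O=Cc1ccc(-c2cn3ccnc3c(-c3ccc4ncn(Cc5ccccc5)c4c3)n2)cc1`, gives 0.53% in this assay.
Compound 3, `c1cn2cc(-c3ccc4c(c3)ncn4C3CCCCC3)nc(-c3ccc4ncn(C5CCCCC5)c4c3)c2n1`, gives 18.8% in this assay.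

Compounds 1 and 2 share a core and differ only by benzyl in place of cyclohexyl on an aromatic nitrogen. That change produced no change at the digits printed from compound 1 to compound 2 (within the scatter), so the two values show no movement. Compound 3 stands apart: the difference between its core and that of compound 1 is not broken down here, and its value is the highest of the three, lying beyond the scatter from both compound 1 and compound 2.

Compound 4, `c1ccc(Cn2cnc3ccc(-c4nc(-c5ccc6c(c5)ncn6C5CCCCC5)cn5ccnc45)cc32)cc1`, has not yet been measured in this assay. It is related to compound 3 by benzyl in place of cyclohexyl on an aromatic nitrogen, the same change that links compound 1 to compound 2, at a place described in identical words. Since that change left compound 1 and compound 2 within the scatter of each other, the step expected from compound 3 to compound 4 is small, namely a number 1.8 percentage points lower from compound 3 to compound 4 (within the scatter). On that basis compound 4 is estimated at 17%, with a likely range from 5% to 30%.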

Compound 4, a percentage reported as inhibition, at one concentration (the size of the read-out at that concentration, not a potency): -63.1%
Compound 4: the middle estimate sits 80.1 percentage points above what was measured; measured number below the stated range.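

In this assay, benzyl in place of cyclohexyl on an aromatic nitrogen went with a number 81.9 percentage points lower from compound 3 to compound 4 (beyond the scatter), whereas the same change had left the values on the earlier core level. Going by these compounds alone, the change therefore did not carry from one core to the other with the same result: the same change on two cores in this assay, no change at the digits printed (within the scatter) from compound 1 to compound 2 and a number 81.9 percentage points lower (beyond the scatter) from compound 3 to compound 4, 81.9 percentage points apart, beyond the scatter of two such steps This shows that the flat step on the core of compound 1 cannot be read across to the core of compound 3, but with only one pair on each core, it does not show which difference between the cores matters, how the change would behave on a third core, or what the negative reading of compound 4 at -63.1% means.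

The compounds shown leave open what a methyl, a longer alkyl chain or a chain ending in an amine on that nitrogen would do on either core. Also open, from the compounds shown here alone, is whether a carboxylic acid in place of the carbonyl-bearing end of compound 1 would make that core respond to the change as the core of compound 3 does.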